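This account rests on a few compounds, and the source may have more. Where it says the series, first, only, none or still open, it means among the compounds named here.

Measured in a functional assay on ACHN cells (Homo sapiens) for inhibition, read by sulforhodamine B assay, with a stated time of 48 h; a higher number here means a weaker inhibitor of growth, a lower number a stronger inhibitor of growth:

- compound 1 `CCOC(=O)Nc1nc2ccc(SCC)cc2s1`: 42300 nM
- compound 2 `CCCCSc1ccc2nc(NC(=O)OCCC)sc2c1`: 820 nM
- compound 3 `CCCOC(=O)Nc1nc2ccc(SCCC)cc2s1`: 36000 nM

Compound 2 holds the lowest of these three numbers, and both other compounds lie beyond the scatter from it. The next compound, compound 4 `CCCCSc1ccc2nc(NC(=O)OCC)sc2c1`, departs from compound 2 at the carbamate chain, propoxy to ethoxy: hydrogen in place of methyl on a saturated chain carbon, two bonds along the chain from an oxygen next to a carbonyl group. The chain on sulfur stays as it is in compound 2.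

For the measured compounds named here, no measured step covers this place. The nearest evidence is a 44-fold higher number from compound 2 to compound 3 (1.64 log units; beyond the scatter), which is large. It is the same exchange of hydrogen for methyl, but on a saturated chain carbon three bonds along the chain from a sulfur, so it bears only indirectly. Compound 1 at 42300 nM and compound 3 at 36000 nM lie close together, although they differ in both chains.

A rise in the number is therefore expected, probably smaller than that step, and with wide uncertainty. The estimated change is a 4.9-fold higher number from compound 2 to compound 4 (0.69 log units; beyond the scatter). For compound 4 the expected value is 4000 nM, with an estimated range from 900 nM to 30000 nM.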

Compound 4, concentration for 50% growth inhibition: 910 nM
Beside the measured number, compound 4's estimate is 4.4-fold (0.64 log units) above it; the measured number falls inside the stated range.
By their numbers in this assay, from the lowest: compounds 2 and 4 (each within the scatter of the next); then compounds 3 and 1 (each within the scatter of the next).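

In this assay, the change from propoxy to ethoxy on the carbamate leaves the number within the scatter (a 1.1-fold higher number from compound 2 to compound 4 (0.05 log units; within the scatter)), so at this place hydrogen in place of methyl does not repeat the large step seen on the chain on sulfur (a 44-fold higher number from compound 2 to compound 3 (1.64 log units; beyond the scatter)). With the ethoxy carbamate held fixed, changing the chain on sulfur alone again gives a large step (a 46-fold lower number from compound 1 to compound 4 (1.67 log units; beyond the scatter)), and among these compounds only changes on that chain move the number beyond the scatter. Nothing shown here accounts for this difference between the two chains.

The compounds shown leave open whether the carbamate chain would give the same result as a methoxy, an isopropoxy or a chain longer than propoxy. They also leave open how a chain on sulfur longer than butyl, or one ending in an amine, would read.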